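The source may hold more compounds than are shown below. What is called first, only, known or untested is meant among the compounds shown, and "the series" means these compounds.

On the shared core, compound 3 `Cc1ncnc2[nH]cc(Sc3cccs3)c12` gives only a limit in a functional assay on K562-TAX cells (Homo sapiens), read by MTT assay, with a stated time of 3 days (on this read-out higher numbers stand for weaker inhibition and lower numbers for stronger inhibition), > 50000 nM. Compound 1 `CNc1ncnc2[nH]cc(Sc3cccs3)c12` reads 21000 nM and compound 2 `c1coc(-c2ncnc3[nH]cc(Sc4cccs4)c23)c1` reads 18900 nM, and between them the record shows a 1.1-fold lower number from compound 1 to compound 2 (0.05 log units; within the scatter). Compound 4 `COc1ncnc2[nH]cc(Sc3cccs3)c12` has methoxy in place of methyl on an aromatic carbon, (methoxy in place of methyl on an aromatic carbon). Going by the values given here, no measured step involves methoxy. The nearest evidence is the replacement of methylamino by methyl, an at least 2.3-fold higher number from compound 1 to compound 3 (0.37 log units; beyond the scatter), and of furan-2-yl by methyl, an at least 2.6-fold higher number from compound 2 to compound 3 (0.42 log units; beyond the scatter). Read in reverse, both suggest that replacing methyl in compound 3 may lower the number, with methylamino the closer guide. The estimated step is an at least 1.7-fold lower number from compound 3 to compound 4 (0.25 log units; that floor lies within the scatter), which is expected to be modest. For compound 4 the estimate in this assay is 28000 nM, with an expected range of 13000 nM to 50000 nM.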

Compound 4, half-maximal inhibitory concentration: 44000 nM
Compound 4: the middle estimate sits 1.6-fold (0.20 log units) below what was measured; the range from low to high includes it.
By their numbers in this assay, from the lowest: compounds 2 and 1 (each within the scatter of the next); then compound 4. At a limit, above all of these: compound 3.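

In this assay, the change from methyl to methoxy on this aromatic carbon gives an at least 1.1-fold lower number from compound 3 to compound 4 (0.05 log units; that floor lies within the scatter), and methoxy does not match either earlier replacement of methyl, with a 2.1-fold higher number from compound 1 to compound 4 (0.32 log units; beyond the scatter) and a 2.3-fold higher number from compound 2 to compound 4 (0.37 log units; beyond the scatter). Methylamino and methoxy are therefore not interchangeable at this position, although the step between them is modest. Compound 3 gives only a limit: the limit of > 50000 nM in this assay, at which 1 of the 4 values shown sits.

As far as these compounds go, it remains open whether an unsubstituted amine or a longer chain such as ethoxy on this carbon would give a lower number than compound 1 and compound 2.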